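Replacing a Ring-Bearing Hydrazone Arm with an Open Chain

The source may report more compounds than this note shows. Statements on the series, on what has been measured and on what is new or still open speak of the compounds shown alone.

In a functional assay on MCF7 cells (Homo sapiens) for inhibition, read by MTT assay, with a stated time of 48 h (a lower number here means a stronger inhibitor, a higher number a weaker inhibitor), compound 1 `CCOC(=O)c1c(N/N=C2\C(=O)NN=C2C)sc2c1CCCCC2` gives 52400 nM, the highest of the two numbers recorded so far. For the measured compounds named here, its nearest neighbour, compound 2 `CCOC(=O)/C(=N/Nc1sc2c(c1C(=O)OCC)CCCCC2)C(C)=O`, gives 5800 nM in this assay, a lower number that lies beyond the scatter, though no single-point step connects the two structures.

Compound 3 `CCOC(=O)c1c(NN=C(C#N)C#N)sc2c1CCCCC2` has not yet been measured. It differs from compound 1 by a group of 6 heavy atoms (3 carbon, 3 nitrogen; no ring) in place of a group of 8 heavy atoms (4 carbon, 3 nitrogen, 1 oxygen; one five-membered non-aromatic ring with 2 hetero atoms), on a nitrogen on an aromatic ring. Going by the values given here, no measured pair shows the effect of this exact change. The author expects a moderate move to a lower number, just beyond the scatter, a 3.5-fold lower number from compound 1 to compound 3 (0.54 log units; beyond the scatter). For compound 3 in this assay the estimate is 15000 nM, within 4000 nM to 55000 nM.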

Compound 3, half-maximal inhibitory concentration: 8200 nM
For compound 3 the middle estimate is 1.8-fold (0.26 log units) above the measured one, within the range that was stated.
By their numbers in this assay, from the lowest: compounds 2 and 3 (each within the scatter of the next); then compound 1.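

In this assay, putting the group of 6 heavy atoms with no ring in place of the group of 8 heavy atoms with one five-membered non-aromatic ring, on a nitrogen on an aromatic ring, gives a 6.4-fold lower number from compound 1 to compound 3 (0.81 log units; beyond the scatter). For the compounds shown here, this is the first step that changes one place only, and it shows that the value responds to what this nitrogen carries. The change also takes the count of hydrogen-bond donors in the group from 1 to 0 and brings in 2 triple bonds, and no measurement here bears on what lies behind the step.

The compounds shown leave open whether the ring itself or the two nitrile groups account for the step. As far as these compounds go, it also remains open how a group with a single nitrile, or a carboxylic acid in an open chain, would read at this nitrogen.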